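Three amines on one core, a fourth awaits measurement

The compounds below may be only part of what the source reports. "The series", "measured", "known", "first", "only" and "open" are said of these compounds alone.

Three compounds share a core and were measured in an assay on isolated protein for inhibition of ubiquitin carboxyl-terminal hydrolase 7 (Homo sapiens), read by fluorescence, with stated times of 30 min and 1 h; a lower number here means a stronger inhibitor, a higher number a weaker inhibitor. Compound 1 `O=C([C@H]1Cc2cc(Cl)cc(-c3ccnc4cc(C5(O)COC5)sc34)c2O1)N1CCNCC1` gives 73 nM. Compound 2 `Cc1cc(Cl)cc(-c2ccnc3cc(CN4C(=O)CCC4=O)sc23)c1O[C@H]1CCCNC1` gives 4.6 nM. Compound 3 `Cc1cc(Cl)cc(-c2ccnc3cc(CN4C(=O)C5CC5C4=O)sc23)c1C[C@@H]1CNCCO1` gives 0.16 nM. Among these three numbers compound 2 stands second highest: its nearest neighbour is compound 1 with a higher number beyond the scatter, while compound 3 lies furthest, with a lower number also beyond the scatter. Compounds 1 and 3 differ from compound 2 in more than one place, so no single step can be read from either pair; their values alone are known.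

Compound 4 `Cc1cc(Cl)cc(-c2ccnc3cc(CN4C(=O)CCC4=O)sc23)c1O[C@@H]1CCNC[C@@H]1C` is not yet measured. It differs from compound 2 in one place: 3-methylpiperidin-4-yl in place of piperidin-3-yl on an oxygen on an aromatic ring. The ring that leaves and the ring that enters each carry one hydrogen-bond donor and one hydrogen-bond acceptor, and the change is confined to the group on the ether oxygen. Among the compounds with values here, no measured pair in this set isolates such a change, so nothing measured here tells its direction. Compound 4 is therefore expected to stay close to compound 2, with a step of a 1.1-fold higher number from compound 2 to compound 4 (0.04 log units; within the scatter) that does not clearly exceed the scatter. In this assay compound 4 is estimated at 5 nM, within a range from 1.5 nM to 16 nM.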

Compound 4, half-maximal inhibitory concentration: 2.1 nM
For compound 4 the middle estimate is 2.4-fold (0.38 log units) above the measured one; low and high end bracket the measured number.
By their numbers in this assay, from the lowest: compound 3; then compound 4; then compound 2; then compound 1.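

In this assay, replacing piperidin-3-yl with 3-methylpiperidin-4-yl on an oxygen on an aromatic ring gives a 2.2-fold lower number from compound 2 to compound 4 (0.34 log units; beyond the scatter), a modest step but the first in this set that can be read at a single place. It shows that the position responds to a change in the group on the ether oxygen, and that moving to the larger, methyl-bearing ring, with one more defined stereocentre, does not cost potency, although both rings have six members and the same hydrogen-bond donor and acceptor counts. No independent evidence bears on why the number falls, and compounds 1 and 3 differ from the others in more than one place, so no step to either can be read.

The step combines two differences, the point of attachment on the piperidine ring and the added methyl, so the compounds shown leave open which of them matters; plain piperidin-4-yl on the same oxygen would separate the two. Also open, on these data alone, are the effect of the other stereoisomers of 3-methylpiperidin-4-yl and how a pyrrolidin-3-yl ring or an open-chain 2-aminoethyl group would fare here.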